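The source may report more compounds than this note shows. Statements on the series, on what has been measured and on what is new or still open speak of the compounds shown alone.

Compound 2, `CCCn1c(=O)[nH]c2nc(-c3ccc(S(=O)(=O)N4CCN(c5ccc(Br)cc5)CC4)cc3)[nH]c2c1=O`, was assessed in an assay on CHO cells for displacement of a labelled ligand from adenosine receptor A2b (Homo sapiens), read by scintillation counting, with a stated time of 75 min, in the presence of a further agent that is not named here (a higher number here means a weaker inhibitor, a lower number a stronger inhibitor), where compound 2 gives 0.0835 nM. That is the lowest of the two numbers seen so far. Going by the values given here, the only comparison partner is compound 1, `CCCn1c(=O)[nH]c2nc(-c3ccc(S(=O)(=O)N4CCN(c5ccc(F)cc5)CC4)cc3)[nH]c2c1=O`, for which the value in this assay is 0.644 nM; the single measured step, a 7.7-fold lower number from compound 1 to compound 2 (0.89 log units; beyond the scatter), is the exchange of one halogen for another on the aromatic ring attached to the ring nitrogen.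

The next compound, compound 3, `CCCn1c(=O)[nH]c2nc(-c3ccc(S(=O)(=O)N4CCN(Cc5cccc(C)c5)CC4)cc3)[nH]c2c1=O`, has not yet been measured. It differs from compound 2 by 3-methylbenzyl in place of 4-bromophenyl on an amine nitrogen in a ring. Among the compounds with values here, no measured step concerns this kind of exchange; the step from compound 1 to compound 2 swaps substituents on an aromatic ring that stays directly attached, whereas here that whole ring gives way to a benzyl group with a methyl on it. The measured step therefore offers no guidance in direction, and the expectation rests on the general observation that rather small changes in this series have already moved the number well beyond the scatter. Compound 3 is expected to give a higher number than compound 2, by a step of about a 6.0-fold higher number from compound 2 to compound 3 (0.78 log units; beyond the scatter), so that compound 3 is estimated at 0.5 nM, with a range from 0.08 nM to 3 nM.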

Compound 3, inhibition constant: 0.397 nM
Compound 3: middle estimate off by 1.3-fold (0.10 log units), on the high side; measured number inside the range.
By their numbers in this assay, from the lowest: compound 2; then compounds 3 and 1 (each within the scatter of the next).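

At this position, on an amine nitrogen in a ring, the effect of 3-methylbenzyl in this assay depends on which group it is compared with: against 4-bromophenyl the exchange gives a 4.8-fold higher number from compound 2 to compound 3 (0.68 log units; beyond the scatter) and lies beyond the scatter, whereas against 4-fluorophenyl it gives a 1.6-fold lower number from compound 1 to compound 3 (0.21 log units; within the scatter) and lies within it. The position therefore accepts a benzyl group as well as a directly attached aryl ring without a clear difference from compound 1, and among these three compounds only compound 2 stands apart from the others. Nothing among the available data accounts for the standing of compound 2 or for the match between compound 1 and compound 3.

The compounds shown change the link to the ring and its substituent together, so the separate contributions of the methylene and the methyl group remain unresolved. Unsubstituted benzyl, 4-bromobenzyl and 3-methylphenyl would each separate these two changes, while a longer chain to the aromatic ring or a carboxylic acid on it would test how far this position extends beyond the groups seen here.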